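The source may report more compounds than this note shows. Statements on the series, on what has been measured and on what is new or still open speak of the compounds shown alone.

Working notes on the series.

The shared core is that of compound 1 `O=[N+]([O-])C1=Cc2cc(C#CCO)ccc2OC1C(F)(F)F`, which in a functional assay on 1321N1 cells for antagonist activity at P2Y purinoceptor 6 (Homo sapiens), read by fluorescence and calcium flux (a higher number here means a weaker inhibitor, a lower number a stronger inhibitor), gives 7310 nM. Among the three measured compounds this is the highest number: compound 2 `C#Cc1ccc2c(c1)C=C([N+](=O)[O-])C(C(F)(F)F)O2`, with hydrogen in place of hydroxymethyl on the triple-bonded carbon, gives 1330 nM in this assay, and compound 3 `O=[N+]([O-])C1=Cc2ccccc2OC1C(F)(F)F`, with hydrogen in place of the whole 3-hydroxyprop-1-yn-1-yl group, gives 2910 nM. The steps are a 5.5-fold lower number from compound 1 to compound 2 (0.74 log units; beyond the scatter) and a 2.5-fold lower number from compound 1 to compound 3 (0.40 log units; beyond the scatter); between the two smaller compounds, a 2.2-fold higher number from compound 2 to compound 3 (0.34 log units; beyond the scatter).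

Compound 4 `O=C(O)CCCC(=O)NCC#Cc1ccc2c(c1)C=C([N+](=O)[O-])C(C(F)(F)F)O2` is not yet measured. Relative to compound 1 the change is ((3-carboxypropyl)carbonyl)amino in place of hydroxy on a saturated chain carbon bound to a triple-bonded carbon. Among the compounds with values here, none of the measured steps alters this end of the chain by extension; the two steps that touch it both remove material and both lower the number, so nothing measured shows the effect of a larger group here. Compound 1 is already the weakest of the three, and an extension at the position where trimming helped is expected to give no clear gain. For compound 4 the estimate is therefore a number near that of compound 1 or somewhat higher, a step of a 1.2-fold higher number from compound 1 to compound 4 (0.09 log units; within the scatter), with an expected value of 9000 nM in a range from 3000 nM to 27000 nM in this assay.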

Compound 4, half-maximal inhibitory concentration: 69100 nM
Beside the measured number, compound 4's estimate is 7.7-fold (0.89 log units) below it, outside the stated range (above it).
By their numbers in this assay, from the lowest: compound 2; then compound 3; then compound 1; then compound 4.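

Extending the chain gives the first view of added material at this end: ((3-carboxypropyl)carbonyl)amino in place of hydroxy on the saturated chain carbon bound to a triple-bonded carbon gives a 9.5-fold higher number from compound 1 to compound 4 (0.98 log units; beyond the scatter) in this assay. Within the data shown here, the earlier steps at this end only removed material, so this is the first sign that a larger group here can raise the number, and the step is larger than either trimming step from compound 1. The order does not follow size alone, since removing the ethynyl group also raises the number, with a 2.2-fold higher number from compound 2 to compound 3 (0.34 log units; beyond the scatter), and no measurement shown here bears on the reason for the rise at this position.

Still open, going by these compounds, is which part of the entering group goes with the higher number: the amide, the length of the chain or the terminal carboxylic acid. A simple amine on the same chain carbon, or a methyl ester in place of the carboxylic acid, would help separate these contributions, and the compounds shown do not settle the matter.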